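Methoxy in Place of Fluoro: A Second Instance

The source may report more compounds than this note shows. Statements on the series, on what has been measured and on what is new or still open speak of the compounds shown alone.

Of the compounds shown here, three sharing one core have been measured in a functional assay on MCF-10A cells (Homo sapiens) for antiproliferative activity, with a stated time of 48 h; a lower number here means that less compound is needed, a higher number that more compound is needed for the effect. Compound 1 `COc1ccc2nc(C)cc(NCc3cccc(F)c3)c2c1` gives 11300 nM. Compound 2 `COc1ccc2nc(C)cc(NCc3ccccc3F)c2c1` gives 14000 nM; it differs from compound 1 by 2-fluorophenyl in place of 3-fluorophenyl on a saturated chain carbon bound to a nitrogen on an aromatic ring, and the step of a 1.2-fold higher number from compound 1 to compound 2 (0.09 log units; within the scatter) lies within the scatter. Compound 3 `COc1cccc(CNc2cc(C)nc3ccc(OC)cc23)c1` gives 9700 nM; it differs from compound 1 by methoxy in place of fluoro on an aromatic carbon, and the step of a 1.2-fold lower number from compound 1 to compound 3 (0.07 log units; within the scatter) is likewise within the scatter. All three numbers sit within the usual scatter of each other, so no order among them can be stated.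

Compound 4 `COc1ccc2nc(C)cc(NCc3ccccc3OC)c2c1` has not yet been measured in this assay. It differs from compound 2 by methoxy in place of fluoro on an aromatic carbon. Among the measured compounds shown here, this is the same kind of change as the one from compound 1 to compound 3, although there the methoxy sits meta to a large group, whereas in compound 4 it sits ortho to a large group. Among the compounds shown, methoxy in place of fluoro occurs twice in all: once measured and once pending.

Compound 4 is expected to lie a step of a 1.2-fold lower number from compound 2 to compound 4 (0.07 log units; within the scatter) from its measured neighbour, because the measured step of a 1.2-fold lower number from compound 1 to compound 3 (0.07 log units; within the scatter) stayed within the scatter. Compound 4 is therefore estimated at 12000 nM, with a likely range from 5000 nM to 30000 nM.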

Compound 4, half-maximal effective concentration: 25200 nM
For compound 4 the middle estimate is 2.1-fold (0.32 log units) below the measured one; the measured number falls inside the stated range.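

In this assay, the second instance of methoxy in place of fluoro, with the methoxy ortho to a large group, gives a 1.8-fold higher number from compound 2 to compound 4 (0.26 log units; within the scatter), so this step, like the first, lies within the scatter. Set beside the earlier instance, the two steps do not differ by more than two such steps can scatter: the same change on two cores in this assay, a 1.2-fold lower number (0.07 log units; within the scatter) from compound 1 to compound 3 and a 1.8-fold higher number (0.26 log units; within the scatter) from compound 2 to compound 4, 2.1-fold (0.32 log units) apart, within the scatter of two such steps In this series, the change can therefore be carried between these two cores without any detectable difference in its step, but two pairs are a narrow base, and they show neither that the step is truly the same on both cores nor that it would hold on any other core.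

The compounds shown leave open whether a larger step would appear if a group of another kind, such as an amine, a carboxylic acid or a longer chain like butoxy, stood in place of the fluoro or methoxy on the six-membered aromatic ring of carbon only. They also leave open how far the numbers in this assay can move when the shared core itself is changed, since every step seen so far lies within the scatter.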